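Cytotoxicity of the aminothiazole series: compound 3 to compound 4

The source may report more compounds than this note shows. Statements on the series, on what has been measured and on what is new or still open speak of the compounds shown alone.

Working notes on the series. In an ADME assay on HepG2 2.2.15 cells (Homo sapiens) for cytotoxicity (a lower number here means that less compound is tolerated, a higher number that more compound is tolerated), compound 1 `O=C(Nc1ncc(Cc2ccc(Cl)cc2)s1)c1cccs1` gives > 50000 nM, a limit of the assay rather than a number. Compound 2 `CC(C)(C)OC(=O)Nc1ncc(C(Oc2ccc(Cc3ccccc3)cc2)c2ccc(Cl)cc2)s1` likewise reaches > 50000 nM in this assay, again a limit. Compound 3 `CCOC(=O)CCCNc1ncc(C(Oc2ccc3cc(Br)ccc3c2)c2ccc(Cl)cc2)s1` is recorded in this assay only as "not toxic" (no number reported), so no single number places it; the two other values shown sit at the limit of > 50000 nM in this assay, at which 2 of the 3 values shown sit. Compound 4 `O=S(=O)(Nc1ncc(C(Oc2ccc3cc(Br)ccc3c2)c2ccc(Cl)cc2)s1)c1ccccc1` differs from compound 3 by phenylsulfonyl in place of 3-(ethoxycarbonyl)propyl on a nitrogen on an aromatic ring. No measured step between any two compounds is shown, so the size of the step in this assay is an open question; with every value so far at or described as a limit, no step beyond the scatter is expected. Compound 4 is therefore estimated at 60000 nM in this assay, within 15000 nM to 200000 nM.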

Compound 4, half-maximal cytotoxic concentration: > 50000 nM
Compound 4 ended at the assay's limit; the forecaster's own chance of this, stated with the estimate: 70%; the middle value lies beyond the limit too.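

Going by these compounds alone, no step from compound 3 to compound 4 can be read: compound 3 has no number, and compound 4 stands at a limit. The compounds shown leave open at what concentration, if any, cytotoxicity appears in this assay.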